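Trimming the phenyl group of compound 1

The source may hold more compounds than are shown below. What is called first, only, known or untested is meant among the compounds shown, and "the series" means these compounds.

Compound 1 `CN1CCN(CCCOc2cccc3nc(Nc4ccc(Cl)c(C(F)(F)F)c4)ccc23)CC1` gives 3380 nM
Compound 2 `CN1CCN(CCCOc2cccc3nc(Nc4ccc(F)c(F)c4)ccc23)CC1` gives 4400 nM

Among the measured compounds shown here, only these two compounds have been measured in a functional assay on cells (Panel melanoma (Carcinoma cell lines), Homo sapiens) for inhibition, read by sulforhodamine B assay, with a stated time of 48 h (a lower number here means a stronger inhibitor of growth, a higher number a weaker inhibitor of growth), and they cannot be told apart, so compound 1 stands level with its sole neighbour (a 1.3-fold higher number from compound 1 to compound 2 (0.11 log units; within the scatter)). Compound 3 `CN1CCN(CCCOc2cccc3nc(Nc4cccc(Cl)c4)ccc23)CC1` is still unmeasured and changes the same place (3-chlorophenyl in place of 4-chloro-3-(trifluoromethyl)phenyl on a nitrogen on an aromatic ring). Replacing that group to give compound 2 stayed within the scatter (a 1.3-fold higher number from compound 1 to compound 2 (0.11 log units; within the scatter)), so no step beyond the scatter is expected here. The expected step is small (a 1.1-fold higher number from compound 1 to compound 3 (0.05 log units; within the scatter)). For compound 3 the estimate is 3800 nM with an expected range (1900 nM to 7500 nM).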

Compound 3, concentration for total growth inhibition: 3370 nM
Compound 3: the middle estimate sits 1.1-fold (0.05 log units) above what was measured; low and high end bracket the measured number.
By their numbers in this assay, from the lowest: compounds 3, 1 and 2 (each within the scatter of the next).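

In this assay, the smaller 3-chlorophenyl group cannot be told apart from the larger 4-chloro-3-(trifluoromethyl)phenyl group (a 1.0-fold lower number from compound 1 to compound 3 (0.00 log units; within the scatter)) or from 3,4-difluorophenyl (a 1.3-fold lower number from compound 2 to compound 3 (0.12 log units; within the scatter)). Three differently substituted phenyl groups on this nitrogen now give matching numbers, so in these compounds the trifluoromethyl group is not needed to hold the number. Nothing available explains this lack of difference. Still open, going by these compounds, is whether any group here moves the number beyond the scatter, such as unsubstituted phenyl, a pyridine ring or a cyclohexyl group.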